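Urea to aminomethyl-cyclohexenyl on the amine chain

A few compounds are considered here, and "the series" means these few. Any claim that something is new, unique, unknown or untested is made for them only; others in the source may bear on it.

Within this pair, compound 2 `NC(=O)NC/C=C\CN(C[C@H]1Cc2ccccc2CN1)[C@H]1CCCc2cccnc21` holds the highest number: in a functional assay on CCRF-CEM cells for antagonist activity at C-X-C chemokine receptor type 4 (Homo sapiens), read by calcium flux, with stated times of 25 min and 90 s (a lower number here means a stronger inhibitor, a higher number a weaker inhibitor), compound 2 gives 210 nM, while compound 1 `C/C(CN)=C(\F)CN(C[C@H]1Cc2ccccc2CN1)[C@H]1CCCc2cccnc21` gives 28 nM. For the measured compounds named here, the one measured step, a 7.5-fold higher number from compound 1 to compound 2 (0.88 log units; beyond the scatter), is the only comparison on record, and it bears directly on the change to compound 3 `NCC1=C(CN(C[C@H]2Cc3ccccc3CN2)[C@H]2CCCc3cccnc32)CCCC1`, which is a group of 8 heavy atoms (7 carbon, 1 nitrogen; one six-membered non-aromatic ring of carbon only) in place of a group of 7 heavy atoms (4 carbon, 2 nitrogen, 1 oxygen; no ring), on a saturated chain carbon bound to an amine nitrogen. Going by the values given here, the group that enters carries a primary amine on a methylene, as does the group present in compound 1, so the change to compound 3 undoes the part of the step from compound 1 to compound 2 that removed that amine, though the ring is new and no measured compound shows what it adds. A downward step, about as large as the measured one and in the opposite direction, is therefore expected, that is a 5.3-fold lower number from compound 2 to compound 3 (0.72 log units; beyond the scatter). For compound 3 in this assay the estimate is 40 nM, within 12 nM to 150 nM.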

Compound 3, half-maximal inhibitory concentration: 230 nM
Compound 3: the middle estimate sits 5.8-fold (0.76 log units) below what was measured; the measured number lies above the stated range.
By their numbers in this assay, from the lowest: compound 1; then compounds 2 and 3 (each within the scatter of the next).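

In this assay, the primary amine on a methylene is not enough on its own at this position: a 1.1-fold higher number from compound 2 to compound 3 (0.04 log units; within the scatter) leaves these two compounds within the scatter of each other, although 2-(aminomethyl)cyclohex-1-en-1-yl carries that amine and the group it replaces does not. The two aminomethyl groups are also not interchangeable on this saturated chain carbon bound to an amine nitrogen, as an 8.2-fold higher number from compound 1 to compound 3 (0.91 log units; beyond the scatter) is a step beyond the scatter, with 2-(aminomethyl)cyclohex-1-en-1-yl in place of 2-(aminomethyl)-1-fluoroprop-1-en-1-yl. No measurement at hand bears on the reason for this result.

As far as these compounds go, whether the step from compound 1 to compound 3 follows the new ring or the missing fluorine stays open. A 2-(aminomethyl)prop-1-en-1-yl group, the same chain without fluorine, would separate the two, and a hydroxymethyl in place of the aminomethyl on the six-membered ring would test the amine itself.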